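Isopropyl in place of cyclohexyl on a stable ester

This account rests on a few compounds, and the source may have more. Where it says the series, first, only, none or still open, it means among the compounds named here.

Measured compounds:
Compound 1 `C[C@@H](O)[C@H]1C(=O)N2C(C(=O)OCOC(=O)C3CCCCC3)=C(S[C@@H]3CN[C@H](C(=O)Nc4cccc(C(=O)O)c4)C3)[C@H](C)[C@H]12`: > 95%
Compound 2 `Cc1oc(=O)oc1COC(=O)N1C[C@@H]2C[C@H]1C(=O)Nc1cccc(c1)C(=O)OCc1oc(=O)oc1COC(=O)C1=C(S2)[C@H](C)[C@@H]2[C@@H]([C@@H](C)O)C(=O)N12`: > 95%
Compound 3 `Cc1oc(=O)oc1COC(=O)C1=C(S[C@@H]2CN[C@H](C(=O)Nc3cccc(C(=O)OCc4oc(=O)oc4C)c3)C2)[C@H](C)[C@@H]2[C@@H]([C@@H](C)O)C(=O)N12`: > 95%

These three compounds were tested in a physicochemical assay for metabolic stability, read by LC-MS, in phosphate buffer, with a stated time of 3 h, at pH 7.4, tested at 50 uM; a higher number here means that more of the compound is left, a lower number that less of the compound is left. For compound 1 the value of > 95% is a limit of the assay and not a number. The same holds for compound 2, whose > 95% is a limit. Compound 3 likewise gives > 95%, again a limit. All three therefore sit at the limit of > 95% in this assay, at which 3 of the 3 values shown sit, so nothing further can be read about differences between them in this assay.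

The unmeasured compound 4 `CC(C)C(=O)OCOC(=O)C1=C(S[C@@H]2CN[C@H](C(=O)Nc3cccc(C(=O)O)c3)C2)[C@H](C)[C@@H]2[C@@H]([C@@H](C)O)C(=O)N12` is derived from compound 1 by a single change, (isopropyl in place of cyclohexyl on a carbonyl carbon). Nothing else in the structure moves, and the stated place of the change lies on the ester that links to the rest of the shared core.

Among the compounds with values here, no step between measured compounds has been recorded, so any expectation for compound 4 rests on the fact that compound 1 and both others sit at the limit. Compound 4 is expected to stay there too, with a step that the limit leaves unreadable from compound 1 to compound 4 that is none beyond the scatter. Compound 4 is estimated at 96%, within 88% to 100%.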

Compound 4, percent of the compound remaining: > 95%
Compound 4: only a limit was reported; the forecaster's own chance of this, stated with the estimate: 80%; the middle value does not contradict the limit.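

In this assay compound 4 gives > 95%, which is a limit and not a number. Compound 1 also sits at a limit, so no step can be read between compound 1 and compound 4: the limit of > 95% in this assay, at which 4 of the 4 values shown sit.

As far as these compounds go, whether isopropyl and cyclohexyl on this ester differ at all in how much compound remains stays open.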